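The source may hold more compounds than are shown below. What is called first, only, known or untested is meant among the compounds shown, and "the series" means these compounds.

The study compares three compounds in a functional assay on BGC-823 cells (Homo sapiens) for antiproliferative activity, read by MTT assay, tested at 5 uM; a lower number here means a weaker effect, a higher number a stronger effect of the compound at the concentration tested. Compound 1, `COc1cc(C(=O)N/N=C/c2ccccc2C(F)(F)F)cc(OC)c1OC`, gives 35.6% in this assay. Compound 2, `COc1cc(C2=NN(C(C)=O)C(c3cccc(OC)c3OC)O2)cc(OC)c1OC`, gives 17.5% in this assay, the lower of the two numbers; the reading of compound 1 is higher than that of compound 2 by a gap beyond the usual scatter. The two compounds differ in more than one place, so their values show only that the two molecules behave differently here, not which part is responsible.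

Compound 3, `COc1cc(C2=NN(C(C)=O)C(c3ccccc3F)O2)cc(OC)c1OC`, keeps the core of compound 2 and changes a single group: 2-fluorophenyl in place of 2,3-dimethoxyphenyl on a saturated ring carbon. Among the measured compounds shown here, no measured pair in the set isolates this change, so its effect has to be guessed from the two numbers available. Compound 2 gives 17.5%, and the replacement removes both hydrogen-bond acceptors of the leaving group while keeping an aromatic ring in the same place. The step from compound 2 to compound 3 is expected to be small, a number 4.5 percentage points higher from compound 2 to compound 3 (within the scatter), not clearly beyond the scatter. Compound 3 is therefore estimated at 22%, between 8% and 40%.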

Compound 3, a percentage reported as inhibition, at one concentration (the size of the read-out at that concentration, not a potency): 32.8%
Beside the measured number, compound 3's estimate is 10.8 percentage points below it; the measured number falls inside the stated range.
By their numbers in this assay, from the lowest: compound 2; then compounds 3 and 1 (each within the scatter of the next).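

Among the compounds shown here, with the shared core held fixed, putting 2-fluorophenyl in place of 2,3-dimethoxyphenyl gives in this assay a modest change, a number 15.3 percentage points higher from compound 2 to compound 3 (beyond the scatter), and this is the first step in the set that can be read at a single place. It shows that the reading responds to the group on this saturated ring carbon, next to the ring nitrogen and the ring oxygen, even though a six-membered aromatic ring of carbon stays there and the group that leaves has 2 hydrogen-bond acceptors where the group that enters has 0. Nothing available explains this step.

For the compounds shown here, the single step swaps the whole aryl group, so it leaves open whether the higher reading goes with the loss of the methoxy groups, with the arrival of the fluorine, or with both together. Going by these compounds, a plain phenyl, a 2-methoxyphenyl or a 2-chlorophenyl on the same carbon would begin to separate these possibilities, and how far the step holds at other concentrations also stays open.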